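One Added Methyl on a Ring Carbon

The source may report more compounds than this note shows. Statements on the series, on what has been measured and on what is new or still open speak of the compounds shown alone.

Among the compounds with values here, in a functional assay on the whole organism with Rattus norvegicus as the target (a higher number here means that more compound is needed for the effect, a lower number that less compound is needed), compound 2 `N#Cc1ccccc1OCC(O)CNCC(=O)Nc1ccc(C2=NNC(=O)CC2)cc1` gives 14 umol/kg, the higher of the two numbers measured so far. Compound 1 `COc1ccccc1OCC(O)CNCC(=O)Nc1ccc(C2=NNC(=O)CC2C)cc1` gives 3 umol/kg, a gap beyond the usual scatter, so less of compound 1 is needed for the effect. These two compounds differ in more than one place, so their gap cannot be tied to any single change.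

Compound 3 `CC1CC(=O)NN=C1c1ccc(NC(=O)CNCC(O)COc2ccccc2C#N)cc1` alters compound 2 in one place: methyl in place of hydrogen on a saturated ring carbon. Within the data shown here, compound 1 also carries a methyl on that ring carbon, and its value of 3 umol/kg is the only guide, since no measured pair isolates this change. The expected result is a moderately lower number in this assay, estimated as a 2.3-fold lower number from compound 2 to compound 3 (0.37 log units; beyond the scatter). For compound 3, the estimated value is 6 umol/kg, with an expected range from 2 umol/kg to 18 umol/kg.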

Compound 3, dose for half-maximal effect: 0.9 umol/kg
Compound 3: the middle estimate sits 6.7-fold (0.82 log units) above what was measured; measured number outside the range, below it.
By their numbers in this assay, from the lowest: compound 3; then compound 1; then compound 2.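

In this assay the methyl on the saturated ring carbon now has a measured effect of its own, with a 16-fold lower number from compound 2 to compound 3 (1.19 log units; beyond the scatter) as a large step for a single added carbon. Among compounds that carry this methyl, cyano in place of methoxy on the aromatic carbon also matters, with a 3.3-fold lower number from compound 1 to compound 3 (0.52 log units; beyond the scatter) as a modest step. No measurement here accounts for either step.

The compounds shown leave open whether an ethyl or a hydroxymethyl on the same ring carbon would act as the methyl does. They also leave open how a fluorine or an amine in place of cyano on the aromatic carbon would compare with compound 3.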